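From benzoyl to sulfamoyl in an inactive set

The source may hold more compounds than are shown below. What is called first, only, known or untested is meant among the compounds shown, and "the series" means these compounds.

In a functional assay on CCRF-CEM cells (Homo sapiens) for inhibition (on this read-out lower numbers stand for stronger inhibition and higher numbers for weaker inhibition), compound 1 `C#CCN(Cc1ccc2nc(C)nc(O)c2c1)c1ccccc1` gives only a limit (> 10700 nM). Compound 2 `C#CCN(Cc1ccc2nc(C)nc(O)c2c1)c1ccc([N+](=O)[O-])cc1` also gives only a limit (> 4800 nM). Compound 3 `C#CCN(Cc1ccc2nc(C)nc(O)c2c1)c1ccc(C(=O)c2ccccc2)cc1` likewise stands at a limit (> 7700 nM), so no number places it.

Compound 4 `C#CCN(Cc1ccc2nc(C)nc(O)c2c1)c1ccc(S(N)(=O)=O)cc1` carries sulfamoyl in place of benzoyl on an aromatic carbon.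

The measured steps that bear on this change are a step that the two limits leave unreadable from compound 1 to compound 2 and a step that the two limits leave unreadable from compound 1 to compound 3 and also a step that the two limits leave unreadable from compound 2 to compound 3. None of them has a readable size, so no size or direction can be carried over with confidence to this assay. The expected step is a step that the limit leaves unreadable from compound 3 to compound 4. For compound 4 the estimate is 10000 nM, with an expected range from 3000 nM to 30000 nM.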

Compound 4, half-maximal inhibitory concentration: > 26000 nM
Compound 4: a limit, no number; the forecaster's own chance of this, stated with the estimate: 70%; middle value at least 2.6-fold (0.41 log units) from the limit.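

In this assay compound 4 also gives only a limit, > 26000 nM, so its steps from compound 1, compound 2 and compound 3 cannot be read. The compounds shown leave open whether any of these groups changes inhibition at all.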